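Sulfonamide series: benzylamine variation toward compound 4

The compounds below may be only part of what the source reports. "The series", "measured", "known", "first", "only" and "open" are said of these compounds alone.

Three members of the series have been measured in a functional assay on BXPC-3 cells (Homo sapiens) for inhibition, read by MTT assay, with a stated time of 72 h; a lower number here means a stronger inhibitor of growth, a higher number a weaker inhibitor of growth. Compound 1 `COc1ccc(CNCCCNS(=O)(=O)c2cc(C(F)(F)F)cc(C(F)(F)F)c2)cc1OC` gives 13000 nM. Compound 2 `O=S(=O)(NCCCNCc1cccc(Cl)c1)c1cc(C(F)(F)F)cc(C(F)(F)F)c1` gives 3800 nM. Compound 3 `CN(CCCNS(=O)(=O)c1cc(C(F)(F)F)cc(C(F)(F)F)c1)Cc1ccccc1` gives 39000 nM, the highest of the three numbers, with compound 1 nearest and compound 2 furthest, both gaps beyond the scatter. Two single-change steps are known: a 3.4-fold lower number from compound 1 to compound 2 (0.53 log units; beyond the scatter), and a 10-fold higher number from compound 2 to compound 3 (1.01 log units; beyond the scatter).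

Compound 4 `O=S(=O)(NCCCNCc1ccc(Cl)c(Cl)c1)c1cc(C(F)(F)F)cc(C(F)(F)F)c1` is the next entry. Its change from compound 3 is (3,4-dichlorobenzyl)amino in place of benzyl(methyl)amino on a saturated chain carbon, three bonds along the chain from a sulfonamide nitrogen. The step from compound 2 to compound 3, run in reverse, bears most directly on it: compound 2 carries a (3-chlorobenzyl)amino group and stands at 3800 nM, whereas compound 3 with benzyl(methyl)amino stands at 39000 nM. The step from compound 1 to compound 2 adds that a chlorinated ring did better than the dimethoxy one within these three compounds. A large step downward in this assay is therefore expected, about the size of the reverse of a 10-fold higher number from compound 2 to compound 3 (1.01 log units; beyond the scatter) or slightly more. Compound 4 is expected to give 2500 nM, with a range from 800 nM to 8000 nM. The expected step is a 16-fold lower number from compound 3 to compound 4 (1.19 log units; beyond the scatter).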

Compound 4, concentration for 50% growth inhibition: 1400 nM
Beside the measured number, compound 4's estimate is 1.8-fold (0.25 log units) above it, and the stated range covers the measured number.
By their numbers in this assay, from the lowest: compound 4; then compound 2; then compound 1; then compound 3.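

In this assay, an added chloro on an aromatic carbon of the benzyl ring still lowers the number, a 2.7-fold lower number from compound 2 to compound 4 (0.43 log units; beyond the scatter), so chlorination of this ring has not reached its limit at the 3-chlorophenyl stage. The 3,4-dichlorophenyl group also outperforms 3,4-dimethoxyphenyl on the same chain carbon, a 9.3-fold lower number from compound 1 to compound 4 (0.97 log units; beyond the scatter), while the widest step, a 28-fold lower number from compound 3 to compound 4 (1.44 log units; beyond the scatter), changes the ring and the amine nitrogen together and cannot be divided between them. No measurement available here accounts for these differences.

On these data alone, it remains open how much of that widest step belongs to the methyl on the amine nitrogen and how much to the ring chloro groups, a split that the plain benzylamino group would help to settle. Also open, as far as these compounds go, is how a bromo group on the ring or a longer chain would fare in this assay.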